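From a Chlorophenyl Group to a Pyridyl Group

The source may report more compounds than this note shows. Statements on the series, on what has been measured and on what is new or still open speak of the compounds shown alone.

Compound 2 `CCCCCCCCc1ccc(OCC(=O)Cn2nnnc2-c2ccc(Cl)cc2)cc1` is one of two compounds tested in an assay on microsomes from brain for inhibition of Fatty-acid amide hydrolase 1 (Rattus norvegicus), read by fluorescence and HPLC, with a stated time of 60 min (a higher number here means a weaker inhibitor, a lower number a stronger inhibitor), where compound 2 gives 130 nM and compound 1 `CCCCCCCCc1ccc(OCC(=O)Cn2nnnc2-c2ccccc2)cc1` gives 71 nM. Of the two numbers shown, that of compound 2 is the higher, but the gap to compound 1 lies within the scatter. For the measured compounds named here, the only measured step, a 1.8-fold higher number from compound 1 to compound 2 (0.26 log units; within the scatter), alters the same aromatic group yet does not test the present change: compound 3 `CCCCCCCCc1ccc(OCC(=O)Cn2nnnc2-c2ccncc2)cc1` carries pyridin-4-yl in place of 4-chlorophenyl on an aromatic carbon. Going by the values given here, no measured step bears directly on this, so no shift beyond the scatter is expected. Compound 3 is estimated at 150 nM, within 50 nM to 500 nM. This amounts to an expected 1.2-fold higher number from compound 2 to compound 3 (0.06 log units; within the scatter).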

Compound 3, half-maximal inhibitory concentration: 190 nM
Compound 3: middle estimate off by 1.3-fold (0.10 log units), on the low side; the measured number falls inside the stated range.
By their numbers in this assay, from the lowest: compounds 1, 2 and 3 (each within the scatter of the next, the first and the last beyond it).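

The swap of 4-chlorophenyl for pyridin-4-yl gives a 1.5-fold higher number from compound 2 to compound 3 (0.16 log units; within the scatter), so this exchange alone cannot be told apart from repeat-measurement noise. Set against the unsubstituted phenyl group, however, pyridin-4-yl gives a 2.7-fold higher number from compound 1 to compound 3 (0.43 log units; beyond the scatter), the first step at this position to pass beyond the scatter, though only modestly. Nothing available explains this shift. Still open, going by these compounds, is how a pyridin-3-yl group, with its ring nitrogen placed differently, or a phenyl ring carrying a methoxy group or a carboxylic acid would behave at this position.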